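The source may report more compounds than this note shows. Statements on the series, on what has been measured and on what is new or still open speak of the compounds shown alone.

Measured so far:
- compound 1, `Nc1ccccc1NC(=O)c1ccc(CSC(=S)N2CCN(Cc3ccccn3)CC2)cc1`: 61.4%
- compound 2, `Nc1ccccc1NC(=O)c1ccc(CSC(=S)N2CCN(Cc3cccnc3)CC2)cc1`: 78%

Both were tested in a functional assay on HeLa cells (Homo sapiens) for antiproliferative activity, read by CCK-8 assay, with a stated time of 72 h, tested at 8 uM; a higher number here means a stronger effect of the compound at the concentration tested, a lower number a weaker effect. Compound 2 stands highest of the two numbers; the nearest is compound 1, which lies lower, and that gap is beyond the scatter. Within the data shown here, the single measured step, a number 16.6 percentage points higher from compound 1 to compound 2 (beyond the scatter), changes only which ring position of a pyridine is joined to the chain carbon.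

Compound 3, `Nc1ccccc1NC(=O)c1ccc(CSC(=S)N2CCN(C3CCCCC3)CC2)cc1`, is not yet measured. It differs from compound 2 in one place: cyclohexyl in place of (pyridin-3-yl)methyl on an amine nitrogen in a ring. The measured step from compound 1 to compound 2 bears on this change only loosely, since it kept the (pyridin-3-yl)methyl group's ring and merely moved its attachment; here the whole group leaves and a cyclohexyl enters directly on the ring nitrogen. Among the measured compounds shown here, with no measured step that covers such a change, the direction cannot be read from the data. A modest step is expected, a number 12 percentage points lower from compound 2 to compound 3 (beyond the scatter), reflecting that the two measured compounds sit in a fairly narrow band. For compound 3 the estimated read-out is 66%, within a range from 45% to 85%.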

Compound 3, a percentage reported as inhibition, at one concentration (the size of the read-out at that concentration, not a potency): 76.1%
Estimate against measurement, compound 3: 10.1 percentage points below; the measured number falls inside the stated range.
By their numbers in this assay, from the lowest: compound 1; then compounds 3 and 2 (each within the scatter of the next).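

In this assay, putting cyclohexyl in place of (pyridin-3-yl)methyl on the amine nitrogen in a ring gives a number 1.9 percentage points lower from compound 2 to compound 3 (within the scatter), so this large swap leaves the read-out unresolved from that of compound 2, even though the aromatic ring, the pyridine nitrogen and the chain carbon all leave together. The earlier pair showed only that moving the attachment point on the pyridine could matter; this result shows that, at this position, a pyridine ring is not required for a read-out in this range, and that compound 1 is the one that stands apart, with a number 14.7 percentage points higher from compound 1 to compound 3 (beyond the scatter). Nothing available explains why the pyridin-2-yl compound differs from the other two, or why two such different groups land so close together.

The compounds shown leave open how a benzyl group, which keeps an aromatic ring and the chain carbon without the ring nitrogen, or a cyclohexylmethyl group, or a short open chain such as ethyl would behave on this nitrogen. They also leave open whether compound 2 and compound 3 would still match at other concentrations, as each number is a single read-out and not a potency.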